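From phenyl to 4-chlorophenyl in the series

A few compounds are considered here, and "the series" means these few. Any claim that something is new, unique, unknown or untested is made for them only; others in the source may bear on it.

Among the measured compounds shown here, the series has two measured compounds so far. Compound 1 `CCOC(=O)c1nn(-c2ccccc2)c(-c2ccc(Br)cc2)c1CNC(C)(C)C` gives 71900 nM; > 509000 nM (2 entries) in a functional assay on U-251 cells (Homo sapiens) for inhibition, read by sulforhodamine B assay, with a stated time of 48 h; a higher number here means a weaker inhibitor of growth, a lower number a stronger inhibitor of growth. One of the two entries for compound 1 is a limit of the assay and not a number. For the measured compounds named here, compound 2 `CC(C)(C)NCc1c(C(=O)O)nn(-c2ccccc2)c1-c1ccc(Br)cc1` gives 126000 nM in this assay, and it is the only compound here with a single number, so it has no rank to speak of.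

The next compound is compound 3 `CC(C)(C)NCc1c(C(=O)O)nn(-c2ccc(Cl)cc2)c1-c1ccc(Br)cc1`, which differs from compound 2 at one place: chloro in place of hydrogen on an aromatic carbon. This is chloro in place of hydrogen on an aromatic carbon, para to a large group, turning phenyl into 4-chlorophenyl. Going by the values given here, no measured pair shows this change, so its effect has no direct precedent. No step beyond the usual scatter is expected in this assay, and any direction is only a mild lean towards a stronger inhibitor of growth. The expectation takes compound 2 at 126000 nM as its anchor. The expected change is a 1.3-fold lower number from compound 2 to compound 3 (0.10 log units; within the scatter). For compound 3 the estimated value is 100000 nM, with an expected range of 40000 nM to 280000 nM.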

Compound 3, concentration for 50% growth inhibition: > 542000 nM
Compound 3: no number, only a limit; the forecaster's own chance of this, stated with the estimate: 20%; at least 5.4-fold (0.73 log units) between middle value and limit.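

In this assay, chloro in place of hydrogen on an aromatic carbon, para to a large group, gives an at least 4.3-fold higher number from compound 2 to compound 3 (0.63 log units; beyond the scatter). Among the compounds shown here, this is the first reading of any change at this position, and it is not a silent one, although compound 3 carries a limit of the assay and not a number, so the step has a floor but no known size. Such limits are not confined to compound 3, and the scattered entries of compound 1 also advise caution in reading the step's size: the several entries of compound 1 in this assay, 71900 nM; > 509000 nM (2 entries)

On these data alone, whether the step belongs to chloro in particular remains open, as does whether a fluoro or a methoxy on the same aromatic carbon would return a single number in this assay. Also open, as far as these compounds go, is whether phenyl to 4-chlorophenyl gives a step of the same direction when an amide stands in place of the carboxylic acid.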